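The compounds below may be only part of what the source reports. "The series", "measured", "known", "first", "only" and "open" are said of these compounds alone.

In a functional assay on PC-3 cells (Homo sapiens) for cytotoxicity (on this read-out lower numbers stand for an effect already at smaller amounts and higher numbers for an effect only at larger amounts of compound), compound 2 (`COC1=C(C)C(=O)/C(=C(O)/C=C/c2ccccc2OC)C(=O)C1(C)C`) gives 15.6 ug/mL and lies within the scatter of both other compounds, with compound 1 (`COC1=C(C)C(=O)/C(=C(O)/C=C/c2ccc(Br)cc2)C(=O)C1(C)C`) at 17.7 ug/mL and compound 3 (`COC1=C(C)C(=O)/C(=C(O)/C=C/c2ccccc2C)C(=O)C1(C)C`) at 9 ug/mL on the same read-out. Compound 4 (`COC1=C(C)C(=O)/C(=C(O)/C=C/c2c(C)cccc2C)C(=O)C1(C)C`) is not yet measured. It carries 2,6-dimethylphenyl in place of 2-methoxyphenyl (2,6-dimethylphenyl in place of 2-methoxyphenyl on a double-bonded chain carbon bound to a double-bonded chain carbon) on a double-bonded chain carbon bound to a double-bonded chain carbon. The closest measured change (a 1.7-fold lower number from compound 2 to compound 3 (0.24 log units; within the scatter)) put methyl in place of methoxy and stayed within the scatter, as did the other step to compound 3 (a 2.0-fold lower number from compound 1 to compound 3 (0.29 log units; within the scatter)). Among the compounds with values here, no measured compound carries 2,6-dimethylphenyl. A step beyond the scatter in this assay is therefore not expected, and the estimated change (a 1.4-fold lower number from compound 2 to compound 4 (0.15 log units; within the scatter)) remains modest. For compound 4 the expected value is 11 ug/mL within an estimated range from 5.5 ug/mL to 22 ug/mL on repeated measurement.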

Compound 4, concentration for half-maximal effect: 17.1 ug/mL
Beside the measured number, compound 4's estimate is 1.6-fold (0.19 log units) below it, within the range that was stated.
By their numbers in this assay, from the lowest: compounds 3, 2, 4 and 1 (each within the scatter of the next).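

In this assay, the 2,6-dimethylphenyl group at this place, on a double-bonded chain carbon bound to a double-bonded chain carbon, stays within the scatter of 2-methoxyphenyl (a 1.1-fold higher number from compound 2 to compound 4 (0.04 log units; within the scatter)), of 2-methylphenyl with methyl in place of hydrogen on an aromatic carbon (a 1.9-fold higher number from compound 3 to compound 4 (0.28 log units; within the scatter)), and of 4-bromophenyl (a 1.0-fold lower number from compound 1 to compound 4 (0.01 log units; within the scatter)). Replacing 2-methoxyphenyl with a group that has no hydrogen-bond acceptor therefore gives no step beyond the scatter. The compounds shown leave open whether an amine or a carboxylic acid on the aromatic ring would give such a step. No measurement here bears on the reason for these results.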